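Methoxy added to compound 1: an expected step

This account rests on a few compounds, and the source may have more. Where it says the series, first, only, none or still open, it means among the compounds named here.

compound 1 `COc1ccc(CS(=O)(=O)/C=C/c2ccc(F)cc2)cc1`: 1500 nM
compound 2 `COc1ccc(CS(=O)(=O)/C=C/c2ccc(Cl)cc2)cc1`: 2000 nM

Both values come from a functional assay on BT-20 cells (Homo sapiens) for antiproliferative activity, read by trypan blue exclusion; a lower number here means a stronger inhibitor, a higher number a weaker inhibitor. Only these two compounds have been measured, and they lie within the scatter of each other, so compound 1 holds no distinct rank in the series. Within the data shown here, the one measured step, a 1.3-fold higher number from compound 1 to compound 2 (0.12 log units; within the scatter), is chloro in place of fluoro on an aromatic carbon.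

The next compound is compound 3 `COc1ccc(CS(=O)(=O)/C=C/c2ccc(F)cc2OC)cc1`, and the change from compound 1 is methoxy in place of hydrogen on an aromatic carbon. In words, this is methoxy in place of hydrogen on an aromatic carbon. Among the measured compounds shown here, no measured compound carries this change, and the halogen exchange is a different kind of change, so it bears only loosely on the question. The data give no direction. No step beyond the scatter is therefore expected in this assay, though with wide uncertainty, and the expectation stays anchored on compound 1 at 1500 nM. The expected step is a 1.3-fold lower number from compound 1 to compound 3 (0.10 log units; within the scatter). Compound 3 is estimated at 1200 nM, with an expected range from 300 nM to 5000 nM.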

Compound 3, half-maximal inhibitory concentration: 15000 nM
Estimate against measurement, compound 3: 13-fold (1.10 log units) below; the measured number lies above the stated range.
By their numbers in this assay, from the lowest: compounds 1 and 2 (each within the scatter of the next); then compound 3.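

In this assay methoxy in place of hydrogen, ortho to a large group and meta to a fluoro group, gives a 10-fold higher number from compound 1 to compound 3 (1.00 log units; beyond the scatter) and so makes the series' first step beyond the scatter. The earlier halogen exchange, a 1.3-fold higher number from compound 1 to compound 2 (0.12 log units; within the scatter) and thus within the scatter, gave no sign that the aromatic ring of the core could move this read-out; this aromatic carbon now shows that a single added methoxy can weaken inhibition markedly in these cells. Nothing available accounts for the size of this step, so the result stands as an observation without an explanation.

Whether the loss belongs to this aromatic carbon or to methoxy itself remains open, as the compounds shown place no other group here and no methoxy on any other carbon of this ring. A methyl, a hydroxy, an amine or a longer chain such as ethoxy on the same carbon could help separate these two readings, and whether the same step holds with chloro in place of fluoro is equally unsettled.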